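The compounds below may be only part of what the source reports. "The series", "measured", "known", "first", "only" and "open" are said of these compounds alone.

In an ADME assay on L929 cells (Mus musculus) for cytotoxicity, read by resazurin assay, with a stated time of 72 h (a higher number here means a weaker inhibitor, a lower number a stronger inhibitor), compound 1 `O=C(/C=C/c1ccc2c(c1)B(O)OC2)c1ccccc1O` gives > 10 ug/mL, which is a limit of the assay and not a number. Going by the values given here, compound 2 `COc1ccccc1C(=O)/C=C/c1ccc2c(c1)B(O)OC2` gives 6.35 ug/mL, the only actual number so far. Compound 3 `O=C(/C=C/c1ccc2c(c1)B(O)OC2)c1ccccc1F` has fluoro in place of methoxy on an aromatic carbon. Among the compounds with values here, the one measured step bearing on this, an at least 1.5-fold lower number from compound 1 to compound 2 (0.19 log units; that floor lies within the scatter), made that same methoxy group from a hydrogen-bearing oxygen, and it does not clear the scatter. No step beyond the scatter is therefore expected in this assay. The expected change is a 1.1-fold higher number from compound 2 to compound 3 (0.04 log units; within the scatter). The estimate for compound 3 is 7 ug/mL, with a range of 3 ug/mL to 14 ug/mL.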

Compound 3, half-maximal inhibitory concentration: > 10 ug/mL
Compound 3: a limit, no number; the forecaster's own chance of this, stated with the estimate: 25%; middle value at least 1.4-fold (0.15 log units) from the limit.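

Putting fluoro in place of methoxy on this aromatic carbon, ortho to a large group, gives in this assay an at least 1.5-fold higher number from compound 2 to compound 3 (0.19 log units; that floor lies within the scatter). Methoxy thus remains the only one of the three groups shown at this position with an actual number, though this step does not establish a real difference between methoxy and fluoro. The step from compound 1 to compound 3 cannot be read, because both values are limits and not numbers: the limit of > 10 ug/mL in this assay, at which 2 of the 3 values shown sit.

As far as these compounds go, the true values of compound 1 and compound 3 remain open. So does what an amine or a longer chain such as ethoxy would give at this position.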